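Swapping Cyclohexyl for 2-Hydroxypropyl on an Oxygen

A few compounds are considered here, and "the series" means these few. Any claim that something is new, unique, unknown or untested is made for them only; others in the source may bear on it.

- Compound 1 `C=CCO/N=C/c1c(N)ncnc1Oc1ccc(NC(=O)C2(C(=O)Nc3ccc(F)cc3)CC2)cc1F`: 3.65
- Compound 2 `Nc1ncnc(Oc2ccc(NC(=O)C3(C(=O)Nc4ccc(F)cc4)CC3)cc2F)c1/C=N/OCc1ccccc1`: 4.45
- Compound 3 `Nc1ncnc(Oc2ccc(NC(=O)C3(C(=O)Nc4ccc(F)cc4)CC3)cc2F)c1/C=N/OC1CCCCC1`: 4.69

In a physicochemical assay for lipophilicity, using the shake flask method (on this read-out lower numbers stand for lower lipophilicity and higher numbers for higher lipophilicity), compound 3 gives 4.69, which is within the scatter of compound 2 and clearly above compound 1. These three compounds share one core and differ only in the group on a single oxygen.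

Compound 4 `CC(O)CO/N=C/c1c(N)ncnc1Oc1ccc(NC(=O)C2(C(=O)Nc3ccc(F)cc3)CC2)cc1F` has not yet been measured. It carries 2-hydroxypropyl in place of cyclohexyl on that oxygen (2-hydroxypropyl in place of cyclohexyl on an oxygen).

Within the data shown here, three measured steps bear on this change. Among the measured compounds shown here, the closest guide is the only step between an open chain without a ring and cyclohexyl: a number 1.04 log units higher from compound 1 to compound 3 (beyond the scatter). The other two are a number 0.80 log units higher from compound 1 to compound 2 (beyond the scatter) and a number 0.24 log units higher from compound 2 to compound 3 (within the scatter). For the measured compounds named here, no measured compound carries a 2-hydroxypropyl group, so the data give no direct reading of it. The change is therefore expected to be a large fall in this assay, going somewhat beyond the step seen with compound 1.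

The expected step is a number 1.69 log units lower from compound 3 to compound 4 (beyond the scatter).

For compound 4 the estimated value is 3, with an expected range from 2.4 to 3.5.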

Compound 4, partition coefficient: 2.75
Compound 4: the middle estimate sits 0.25 log units above what was measured; measured number inside the range.
By their numbers in this assay, from the lowest: compound 4; then compound 1; then compounds 2 and 3 (each within the scatter of the next).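

In this assay, putting 2-hydroxypropyl on this oxygen gives a number 1.94 log units lower from compound 3 to compound 4 (beyond the scatter), and the same group measured against the other two gives a number 1.70 log units lower from compound 2 to compound 4 (beyond the scatter) and a number 0.90 log units lower from compound 1 to compound 4 (beyond the scatter). The earlier compounds shown here showed only how the number shifts among allyl, benzyl and cyclohexyl, whereas compound 4 now sits lowest of the four and shows that this one position can carry the number well below compound 1. Among these compounds, its 2-hydroxypropyl is also the only group here with a hydrogen-bond donor.

Nothing available explains the size of this fall. 2-hydroxypropyl differs from cyclohexyl at once in its ring, its size and its hydroxyl, and only a matched pair, such as a plain propyl chain or an amine in place of the hydroxyl, could begin to separate these differences.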